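From bromo to methyl in a small inhibitor series

The source may report more compounds than this note shows. Statements on the series, on what has been measured and on what is new or still open speak of the compounds shown alone.

Measured in a functional assay on CCRF-CEM cells (Homo sapiens) for inhibition; on this read-out higher numbers stand for weaker inhibition and lower numbers for stronger inhibition:
Compound 1 `O=C1CCCCC/C1=C\c1ccccc1` gives 110000 nM
Compound 2 `O=C1CCCCC/C1=C\c1cccc(Cl)c1` gives 40500 nM
Compound 3 `O=C1CCCCC/C1=C\c1cccc(Br)c1` gives 137000 nM

The numbers for compound 3 and compound 1 cannot be told apart, as a 1.2-fold higher number from compound 1 to compound 3 (0.10 log units; within the scatter) shows. Compound 2 lies clear of both, and a 3.4-fold higher number from compound 2 to compound 3 (0.53 log units; beyond the scatter) is the largest gap in the set.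

Compound 4 `Cc1cccc(/C=C2\CCCCCC2=O)c1` differs from compound 3 by a single change (methyl in place of bromo on an aromatic carbon) in which methyl takes the place of bromo on an aromatic carbon. Among the measured compounds shown here, no methyl compound has been measured, so the evidence is indirect. For the measured compounds named here, only the steps on that same ring carbon bear on it: a 2.7-fold lower number from compound 1 to compound 2 (0.43 log units; beyond the scatter) was modest and a 1.2-fold higher number from compound 1 to compound 3 (0.10 log units; within the scatter) stayed within the scatter. With steps this small, no step beyond the scatter is expected in this assay for this swap. The expected step is a 1.5-fold lower number from compound 3 to compound 4 (0.18 log units; within the scatter) on this estimate. Compound 4 is expected at 90000 nM with an estimated range from 40000 nM to 200000 nM for a single measurement.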

Compound 4, half-maximal inhibitory concentration: 170000 nM
Beside the measured number, compound 4's estimate is 1.9-fold (0.28 log units) below it; low and high end bracket the measured number.
By their numbers in this assay, from the lowest: compound 2; then compounds 1, 3 and 4 (each within the scatter of the next).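

In this assay methyl on this aromatic carbon cannot be told apart from bromo, with a 1.2-fold higher number from compound 3 to compound 4 (0.09 log units; within the scatter), and it cannot be told apart from hydrogen either, with a 1.5-fold higher number from compound 1 to compound 4 (0.19 log units; within the scatter). Compound 2 therefore remains the only one clear of the others, and a 4.2-fold higher number from compound 2 to compound 4 (0.62 log units; beyond the scatter) is now the widest gap in the set, so of the three groups placed here, only chloro gives a number that differs from that of compound 1. No measurement shown here accounts for chloro standing apart from bromo and methyl.

Going by these compounds, it remains open whether compound 2 is a lone case or whether fluoro, methoxy or an amine on the same carbon would also separate from compound 1. The compounds shown also leave open whether chloro would give the same result on another carbon of the ring.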